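Trimming the chain of compound 1

The source may hold more compounds than are shown below. What is called first, only, known or untested is meant among the compounds shown, and "the series" means these compounds.

For the measured compounds named here, in a functional assay on the whole organism (S2 cells, strain S2) for inhibition, with Drosophila as the target, read by a luciferase reporter, with stated times of 1.5 h and 8 h (a lower number here means a stronger inhibitor, a higher number a weaker inhibitor), compound 1 (`CCCCCCCC(=O)c1c(OC)c(Cl)c(OC)c(Cl)c1OC`) gives 15300 nM as its half-maximal inhibitory concentration, the highest of the three numbers measured so far. Compound 2 (`CCCCCC(=O)c1c(O)c(Cl)c(C)c(Cl)c1O`) gives 3800 nM in this assay and compound 3 (`CCCCCC(=O)c1c(O)cc(OC)c(Cl)c1O`) gives 4600 nM there. These two values lie within the scatter of each other, and both lie lower than the number for compound 1, beyond the scatter.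

Compound 4 (`CCCCCCC(=O)c1c(OC)c(Cl)c(OC)c(Cl)c1OC`) has not been measured. It differs from compound 1 by hydrogen in place of methyl on a saturated chain carbon, six bonds along the chain from a carbonyl carbon in the chain: hydrogen in place of methyl on a saturated chain carbon, six bonds along the chain from a carbonyl carbon.

Going by the values given here, no two measured compounds differ in one place only, so no measured step speaks directly to this change. The change is small as counted, and a step within the scatter is the likeliest outcome in this assay for it. With compound 1 at 15300 nM as the highest number of the set, any shift is expected to go toward a lower number rather than a higher one. The expected change is a 1.3-fold lower number from compound 1 to compound 4 (0.11 log units; within the scatter) and it remains an estimate for now. For compound 4 the estimated value is 12000 nM with an expected range from 6000 nM to 24000 nM in this assay once it is tested.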

Compound 4, half-maximal inhibitory concentration: 16800 nM
For compound 4 the middle estimate is 1.4-fold (0.15 log units) below the measured one; low and high end bracket the measured number.
By their numbers in this assay, from the lowest: compounds 2 and 3 (each within the scatter of the next); then compounds 1 and 4 (each within the scatter of the next).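

In this assay, for the compounds shown here, compound 1 and compound 4 form the first pair that differs in one place only, and the pair gives a 1.1-fold higher number from compound 1 to compound 4 (0.04 log units; within the scatter) on the core of compound 1. Hydrogen in place of methyl on a saturated chain carbon, six bonds along the chain from a carbonyl carbon, therefore leaves the number within the usual scatter, a reading that no earlier pair could give for this position. Nothing in the data shown offers an explanation for this step.

This single step, which can also be read as butyl to propyl when cut further out, does not say how the number responds to a much shorter chain, a longer chain, or an amine or a carboxylic acid at the chain end. Going by these compounds alone, also open is whether the same change would read the same way on the hydroxyl-bearing cores of compound 2 and compound 3, since no pair measured on those cores isolates the chain.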